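The compounds below may be only part of what the source reports. "The series", "measured", "known", "first", "only" and "open" are said of these compounds alone.

Of the compounds shown here, three built on one shared core have been measured in a functional assay on CHO-K1 cells for antagonist activity at adenosine receptor A1 (Homo sapiens), read by a beta-galactosidase reporter and cAMP accumulation, with stated times of 15 min and 6 h; on this read-out higher numbers stand for weaker inhibition and lower numbers for stronger inhibition. Compound 1 `Cc1ccc(-c2nc(N)c3cc(Cc4ccccc4)sc3n2)o1` gives 298 nM. Compound 2 `Cn1cnc(-c2nc(N)c3cc(Cc4ccccc4)sc3n2)c1` gives 2330 nM. Compound 3 `COc1ccccc1Cc1cc2c(N)nc(-c3cccc(C#N)c3)nc2s1` gives 129 nM. Compound 2 therefore stands highest of the three numbers: compound 1 is the nearest, compound 3 the furthest, and both gaps lie beyond the scatter. Among the measured compounds shown here, the only measured step that reaches compound 2 is a 7.8-fold higher number from compound 1 to compound 2 (0.89 log units; beyond the scatter), a swap of the group on the same aromatic carbon of the core, where a five-membered ring took the place of another five-membered ring.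

Compound 4 `Nc1nc(-c2ncccn2)nc2sc(Cc3ccccc3)cc12` has not yet been measured in this assay. pyrimidin-2-yl in place of 1-methyl-1H-imidazol-4-yl on an aromatic carbon

For the measured compounds named here, that single step from compound 1 to compound 2 shows that changing the group on this carbon moves the number by a modest amount, but no measured compound carries pyrimidin-2-yl, so the direction of this new change cannot be read from the data. Because compound 1 with a different ring at this position gave 298 nM, a partial return toward that level is expected, and the step from compound 2 is estimated at a 2.6-fold lower number from compound 2 to compound 4 (0.41 log units; beyond the scatter). For compound 4 the expected value is 900 nM, with an estimated range from 250 nM to 3500 nM.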

Compound 4, inhibition constant: 618 nM
Compound 4: middle estimate off by 1.5-fold (0.16 log units), on the high side; measured number inside the range.
By their numbers in this assay, from the lowest: compound 3; then compound 1; then compound 4; then compound 2.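

With everything else on the shared core unchanged, pyrimidin-2-yl in place of 1-methyl-1H-imidazol-4-yl gives a clear shift in this assay (a 3.8-fold lower number from compound 2 to compound 4 (0.58 log units; beyond the scatter)), even though the two groups have the same counts of heavy atoms, nitrogen atoms and hydrogen-bond acceptors, so this position responds to more than those counts, and the visible difference between the groups is a six-membered aromatic ring for a five-membered one. Set against 5-methylfuran-2-yl, the same group gives a step that also lies beyond the scatter (a 2.1-fold higher number from compound 1 to compound 4 (0.32 log units; beyond the scatter)), so the three groups at this carbon now form an order, with the number for compound 4 lower than that for compound 2 but higher than that for compound 1. No measurement available here explains why these groups differ.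

Compound 3 differs from these compounds in more than one place, so the shown data cannot say how much of its low number comes from the group on this carbon. Also open, on these data alone, is how this position would respond to a pyridin-2-yl ring, with one ring nitrogen, or to a simple amine with no ring at all.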